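Adding a chlorine to the propyl chain of compound 1

This account rests on a few compounds, and the source may have more. Where it says the series, first, only, none or still open, it means among the compounds named here.

This study concerns a small family of compounds sharing one core and measured in an assay for inhibition of 15-hydroxyprostaglandin dehydrogenase [NAD(+)] (Homo sapiens), read by fluorescence, with a stated time of 15 min, in the presence of a further agent that is not named here; on this read-out higher numbers stand for weaker inhibition and lower numbers for stronger inhibition. Compound 1, with the structure `CCC[S+]([O-])c1sc2nc(-c3cccs3)cc(-c3ccccc3)c2c1N`, gives 2.1 nM in this assay. Compound 3, with the structure `COCCC[S+]([O-])c1sc2nc(-c3nccs3)cc(-c3cnc(C)n3C)c2c1N`, gives 3.3 nM, a number that sits within the usual scatter of compound 1. Compound 2, with the structure `CCC[S+]([O-])c1sc2ncccc2c1N`, gives 151 nM, a gap from compound 1 that lies beyond the scatter. So compound 1 stands at the stronger end of what has been measured, with compound 3 keeping it company.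

The next compound, compound 4, has the structure `Nc1c([S+]([O-])CCCCl)sc2nc(-c3cccs3)cc(-c3ccccc3)c12`. It differs from compound 1 in one place: chloro in place of hydrogen on a saturated chain carbon, three bonds along the chain from a sulfur. Nothing else in the molecule changes.

Within the data shown here, no measured pair in this set shows what such an exchange does, so the expectation rests on the smallness of the change itself. Compound 4 is expected to give a number close to that of compound 1, with the step of a 1.2-fold higher number from compound 1 to compound 4 (0.08 log units; within the scatter) lying within the scatter. Compound 4 is therefore estimated at 2.5 nM, with a range from 1 nM to 7 nM.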

Compound 4, half-maximal inhibitory concentration: 4 nM
Compound 4: the middle estimate sits 1.6-fold (0.20 log units) below what was measured, and the stated range covers the measured number.
By their numbers in this assay, from the lowest: compounds 1, 3 and 4 (each within the scatter of the next); then compound 2.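

In this assay, the exchange of propyl for 3-chloropropyl gives a 1.9-fold higher number from compound 1 to compound 4 (0.28 log units; within the scatter), a step within the scatter, so compound 1 and compound 4 cannot be told apart on this read-out. Among these compounds, this is the first pair in the set to differ in only one place, and it shows that, on the core of compound 1, this saturated chain carbon three bonds along from the sulfur can carry a chloro in place of a hydrogen with no measurable loss of inhibition. No available measurement explains why the number stays within the scatter.

This single pair says nothing about how other groups would behave in the same place, such as an amine or a carboxylic acid at the end of the propyl chain, or a longer chain carrying the chlorine. It also leaves open whether the same exchange would give a similarly small step on compound 2, whose number lies far from those of the other compounds, or on compound 3, which carries a different chain and different groups on the core.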